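The source may hold more compounds than are shown below. What is called first, only, known or untested is meant among the compounds shown, and "the series" means these compounds.

Measured so far in a physicochemical assay for lipophilicity; on this read-out lower numbers stand for lower lipophilicity and higher numbers for higher lipophilicity:
- compound 1, `CCCN(C)/N=N/c1ccc(C(=O)O)cc1`: 0.46
- compound 2, `CCCCCCN(C)/N=N/c1ccc(C(=O)O)cc1`: 1.95
- compound 3, `CCCCCCCCN(C)/N=N/c1ccc(C(=O)O)cc1`: 2.77

Compound 3 stands highest of the three numbers in this assay; its nearest neighbour is compound 2 and its furthest is compound 1. The next compound in the series is compound 4, `C#CCN(C)/N=N/c1ccc(C(=O)O)cc1`. Against compound 3 the change is ethynyl in place of heptyl on a saturated chain carbon bound to an amine nitrogen.

For the measured compounds named here, three measured steps bear on this. The step from the shortest to the longest chain gave a number 2.31 log units higher from compound 1 to compound 3 (beyond the scatter); its two parts were a number 1.49 log units higher from compound 1 to compound 2 (beyond the scatter) and a number 0.82 log units higher from compound 2 to compound 3 (beyond the scatter). In all three, each carbon added to the chain raised the number in this assay, and nothing among compounds 1 to 3 goes against that. The move to compound 4 runs the other way: the chain loses five carbons and ends in a triple bond, so a large step downward in this assay is expected, most likely carrying compound 4 below compound 1, whose propyl chain already sits at 0.46. Going by the values given here, no measured compound carries a triple bond, so the size of that extra effect is unknown and the range is set wide.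

For compound 4 the expected step is a number 3.17 log units lower from compound 3 to compound 4 (beyond the scatter), giving an estimate of -0.4, with a range from -1.1 to 0.3.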

Compound 4, partition coefficient: 0
For compound 4 the middle estimate is 0.40 log units below the measured one; the measured number falls inside the stated range.
By their numbers in this assay, from the lowest: compound 4; then compound 1; then compound 2; then compound 3.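

For the compounds shown here, at the saturated chain carbon bound to an amine nitrogen, ethynyl in place of ethyl gives, in this assay, a number 0.46 log units lower from compound 1 to compound 4 (beyond the scatter), the first step that alters the end of the chain and not only its length. The larger steps, a number 2.77 log units lower from compound 3 to compound 4 (beyond the scatter) and a number 1.95 log units lower from compound 2 to compound 4 (beyond the scatter), combine that same change with loss of chain, and much of their size is already matched by the saturated step, a number 2.31 log units higher from compound 1 to compound 3 (beyond the scatter), so the triple bond adds a modest further drop to a large chain-length effect. No measurement in hand gives a reason for the difference between ethynyl and ethyl at this position.

Open, going by these compounds, is whether an allyl group, with a double bond at the same place, would land in the gap between compound 1 and compound 4 in this assay, which would show whether the step tracks the degree of unsaturation. Also open, on these data alone, is whether a triple bond at the end of a longer chain, such as a hexynyl or octynyl group, would give a step of the same size as ethynyl in place of ethyl.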